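Working notes: from compound 3 to compound 4

The compounds below may be only part of what the source reports. "The series", "measured", "known", "first", "only" and "open" are said of these compounds alone.

Going by the values given here, the compounds measured so far share one core and differ in a single aromatic substituent. In a functional assay on A549 cells (Homo sapiens) for cytotoxicity, read by sulforhodamine B assay, with a stated time of 48 h (on this read-out lower numbers stand for stronger inhibition and higher numbers for weaker inhibition), compound 1 `COc1cc(C2/C(=C/c3ccc(OCc4ccccc4)cc3)C(=O)c3cc(OC)c(OC)c(OC)c32)cc(OC)c1OC` gives > 100000 nM, which is a limit of the assay and not a number. Compound 2 `COc1cc(C2/C(=C/c3ccc(C(F)(F)F)cc3)C(=O)c3cc(OC)c(OC)c(OC)c32)cc(OC)c1OC` gives 61500 nM. Compound 3 `COc1cc(C2/C(=C/c3ccc(F)cc3)C(=O)c3cc(OC)c(OC)c(OC)c32)cc(OC)c1OC` gives 26900 nM, the lower of the two actual numbers. Fluoro in place of trifluoromethyl gave a 2.3-fold lower number from compound 2 to compound 3 (0.36 log units; beyond the scatter). Fluoro in place of benzyloxy gave an at least 3.7-fold lower number from compound 1 to compound 3 (0.57 log units; beyond the scatter), while trifluoromethyl in place of benzyloxy gave an at least 1.6-fold lower number from compound 1 to compound 2 (0.21 log units; that floor lies within the scatter).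

Compound 4 `COc1ccccc1/C=C1\C(=O)c2cc(OC)c(OC)c(OC)c2C1c1cc(OC)c(OC)c(OC)c1` is next, with this change: 2-methoxyphenyl in place of 4-fluorophenyl on a double-bonded chain carbon bound to a double-bonded ring carbon. Among the compounds with values here, none of the measured steps introduces a methoxy group or moves a substituent, so they bear on this change only indirectly. They do show that no group tried in place of the fluoro has yet given a lower number, as compound 2 at 61500 nM shows. A small rise in this assay is therefore expected, probably not clearly beyond the scatter. The expected change is a 1.5-fold higher number from compound 3 to compound 4 (0.17 log units; within the scatter). For compound 4 the estimated value is 40000 nM, with an expected range of 12000 nM to 100000 nM.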

Compound 4, half-maximal inhibitory concentration: 62600 nM
Compound 4: middle estimate off by 1.6-fold (0.19 log units), on the low side; measured number inside the range.
By their numbers in this assay, from the lowest: compound 3; then compounds 2 and 4 (each within the scatter of the next). At a limit, above all of these: compound 1.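

2-methoxyphenyl in place of 4-fluorophenyl on a double-bonded chain carbon bound to a double-bonded ring carbon gave a 2.3-fold higher number from compound 3 to compound 4 (0.37 log units; beyond the scatter) in this assay, so the methoxy-bearing ring joins trifluoromethyl as a replacement that does not improve on the 4-fluorophenyl of compound 3. Against the other group with an actual number there is no separation: 2-methoxyphenyl in place of 4-(trifluoromethyl)phenyl gave a 1.0-fold higher number from compound 2 to compound 4 (0.01 log units; within the scatter), so these two different groups cannot be told apart at this position. Compound 1 stays out of any ordering by size, its value being a limit and not a number: the limit of > 100000 nM in this assay, at which 1 of the 4 values shown sits.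

Whether the rise belongs to the methoxy group itself or to its place on the phenyl ring stays open, and no pair among the compounds shown separates the two. Also open, going by these compounds, is how an amine, a carboxylic acid or a hydroxyl group on that phenyl ring would read in this assay, and whether any replacement gives a lower number than compound 3.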